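From methyl to isopropyl on a shared core

This account rests on a few compounds, and the source may have more. Where it says the series, first, only, none or still open, it means among the compounds named here.

Measured in a physicochemical assay for lipophilicity, at pH 7.4; on this read-out lower numbers stand for lower lipophilicity and higher numbers for higher lipophilicity:
Compound 1 `COc1cc2[nH]c(C)c(C3CCCCC3)c(=O)c2cc1Cl`: 3.04
Compound 2 `COc1cc2[nH]c(C)c(C)c(=O)c2cc1Cl`: 1.86

Of these two, compound 2 stands lowest at 1.86, and compound 1 holds the higher number. Compound 3 `COc1cc2[nH]c(C)c(C(C)C)c(=O)c2cc1Cl` departs from compound 2 through (isopropyl in place of methyl on an aromatic carbon), with isopropyl in place of methyl on an aromatic carbon. Within the data shown here, the one measured step that bears on this is a number 1.18 log units lower from compound 1 to compound 2 (beyond the scatter), which is large and beyond the scatter, with methyl in place of cyclohexyl on an aromatic carbon. Read in reverse, it points to a rise in this assay, expected to be smaller than that step but still beyond the scatter. The expected step is a number 0.64 log units higher from compound 2 to compound 3 (beyond the scatter). For compound 3 the estimated value is 2.5, with an expected range of 2.2 to 2.85.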

Compound 3, distribution coefficient: 2.84
The estimate for compound 3 lay 0.34 log units below the measured number, and the stated range covers the measured number.
By their numbers in this assay, from the lowest: compound 2; then compounds 3 and 1 (each within the scatter of the next).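

In this assay the step from methyl to isopropyl (a number 0.98 log units higher from compound 2 to compound 3 (beyond the scatter)) covers most of the range seen at this position on an aromatic carbon. Isopropyl and cyclohexyl cannot be told apart on this read-out (a number 0.20 log units lower from compound 1 to compound 3 (within the scatter)), so the larger cyclohexyl group, with its ring, gives no clear gain over the isopropyl group. No supporting evidence bears on why the numbers fall this way. The compounds shown leave open where ethyl would fall, and whether an amine or a carboxylic acid at this position would bring the number down to or under that of compound 2.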